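Trifluoromethylphenyl urea on a shared core

The compounds below may be only part of what the source reports. "The series", "measured", "known", "first", "only" and "open" are said of these compounds alone.

Measured so far:
compound 1, `O=C(Nc1ccccc1)Nc1cccc(-c2nc(-c3ccc(NC(=O)c4cccnc4)cc3Cl)no2)c1`: > 10000 nM
compound 2, `Cc1ccc(NC(=O)Nc2cccc(-c3nc(-c4ccc(NC(=O)c5cccnc5)cc4Cl)no3)c2)cc1`: 3500 nM

Among the measured compounds shown here, in a functional assay on MDA-MB-231 cells (Homo sapiens) for antiproliferative activity, read by MTT assay, with a stated time of 72 h (a higher number here means a weaker inhibitor, a lower number a stronger inhibitor), compound 2 gives 3500 nM, the only number among the two values shown. For compound 1 the value > 10000 nM is a limit of the assay, not a number. For the measured compounds named here, the one measured step, an at least 2.8-fold lower number from compound 1 to compound 2 (0.45 log units; beyond the scatter), therefore rests on a limit on one side; this is the limit of > 10000 nM in this assay, at which 1 of the 2 values shown sits.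

Compound 3, `O=C(Nc1cccc(-c2nc(-c3ccc(NC(=O)c4cccnc4)cc3Cl)no2)c1)Nc1cccc(C(F)(F)F)c1`, differs from compound 2 by 3-(trifluoromethyl)phenyl in place of 4-methylphenyl on an amide-type nitrogen. The step from compound 1 to compound 2 touches the same ring of the urea, but it concerns a methyl in place of hydrogen, and nothing measured here speaks to a trifluoromethyl group or to a different position on that ring. The step to compound 3 is thus without a direct precedent in these data, and no direction can be read from the measured compounds.

On that footing compound 3 is expected to land near compound 2, with a step of no change at the digits printed from compound 2 to compound 3 (within the scatter) in this assay, and its estimated value is 3500 nM, with a range from 900 nM to 12000 nM.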

Compound 3, half-maximal inhibitory concentration: 1900 nM
Beside the measured number, compound 3's estimate is 1.8-fold (0.27 log units) above it; the range from low to high includes it.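

In this assay, putting 3-(trifluoromethyl)phenyl in place of 4-methylphenyl on an amide-type nitrogen gives a 1.8-fold lower number from compound 2 to compound 3 (0.27 log units; within the scatter), which means that this place tolerates a group with more heavy atoms, carried at a different ring position, with no change that can be told apart from the scatter. The comparison with the unsubstituted phenyl ring now has a second member, since a different substituent at a different ring position gives an at least 5.2-fold lower number from compound 1 to compound 3 (0.72 log units; beyond the scatter), and both substituted compounds therefore stand clear of compound 1. Compound 1 gives > 10000 nM, a limit of the assay and not a number, and both steps from it rest on that limit: the limit of > 10000 nM in this assay, at which 1 of the 3 values shown sits.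

Compound 2 and compound 3 differ in both the substituent and its ring position, leaving open whether either one matters on its own; 3-methylphenyl or 4-(trifluoromethyl)phenyl at this nitrogen would separate the two. Also open, from the compounds shown here alone, is how this place would respond to a ring carrying a methoxy group, an amine or a carboxylic acid, and whether any such group would move the number beyond the scatter.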